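Replacing cyano with isopropyl on compound 3

This account rests on a few compounds, and the source may have more. Where it says the series, first, only, none or still open, it means among the compounds named here.

Going by the values given here, all three compounds measured so far in a functional assay on MT4 cells (Homo sapiens) for cytotoxicity, read by MTT assay (a lower number here means that less compound is tolerated, a higher number that more compound is tolerated), return only a limit. Compound 1 `Cc1c(O)nc(S(=O)(=O)Cc2ccc([N+](=O)[O-])cc2)nc1Cc1c(Cl)cccc1Cl` gives > 53000 nM, which is a limit. Compound 2 `Cc1c(O)nc(SCc2ccc(C#N)cc2)nc1Cc1c(Cl)cccc1Cl` gives > 60000 nM, also a limit. Compound 3 `Cc1c(O)nc(SCc2ccc(C#N)cc2)nc1Cc1c(F)cccc1F` gives > 65000 nM, again a limit, so its standing among the three cannot be ranked.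

Compound 4 `Cc1c(O)nc(SCc2ccc(C(C)C)cc2)nc1Cc1c(F)cccc1F` has isopropyl in place of cyano on an aromatic carbon. Among the compounds with values here, the one measured step, a step that the two limits leave unreadable from compound 2 to compound 3, has 2,6-difluorophenyl in place of 2,6-dichlorophenyl on a saturated chain carbon bound to an aromatic carbon. It bears only loosely on this change, as it lies at another place and has no readable size. Within the data shown here, no measured step touches the cyano group itself.

With compound 3 at > 65000 nM, a limit, no step beyond the scatter is expected in this assay, and any departure is thought more likely to fall toward a lower number. The expected step is an at least 1.3-fold lower number from compound 3 to compound 4 (0.11 log units; that floor lies within the scatter). For compound 4 the estimated value is 50000 nM, with an expected range of 20000 nM to 100000 nM.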

Compound 4, half-maximal cytotoxic concentration: > 62000 nM
Compound 4 ended at the assay's limit; the forecaster's own chance of this, stated with the estimate: 55%; middle value at least 1.2-fold (0.09 log units) away from the limit.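

Compound 3 and compound 4 both return only a limit in this assay, and the step between them, isopropyl in place of cyano, cannot be read. The compounds shown leave open the concentration at which any of them reaches half-maximal cytotoxicity, and whether this swap changes it.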